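The source may report more compounds than this note shows. Statements on the series, on what has been measured and on what is new or still open speak of the compounds shown alone.

Compound 1 `O=C([C@@H]1CCCN(S(=O)(=O)c2ccc(S(=O)(=O)N3CC[C@@H](O)C3)cc2)C1)N1CCC(F)(F)CC1`: 135 nM
Compound 2 `CCN(CC)S(=O)(=O)c1ccc(S(=O)(=O)N2CCC[C@@H](C(=O)NC3CCOCC3)C2)cc1`: 1350 nM

In a functional assay on MIA PaCa-2 cells (Homo sapiens) for inhibition, read by MTT assay, with a stated time of 3 days (on this read-out higher numbers stand for weaker inhibition and lower numbers for stronger inhibition), compound 1 gives 135 nM and compound 2 gives 1350 nM; of these two numbers, compound 2 stands at the higher one, a gap that lies beyond the usual scatter. These two compounds differ in more than one place, so the gap cannot be tied to any single change. Compound 3 `CCN(CC)S(=O)(=O)c1ccc(S(=O)(=O)N2CCC[C@@H](C(=O)N3CCS(=O)(=O)CC3)C2)cc1` has not yet been measured. It keeps the whole of compound 2 except for one group: 1,1-dioxothiomorpholin-4-yl in place of (oxan-4-yl)amino on a carbonyl carbon. Compound 1 also carries a different group on its carbonyl carbon, but it differs from compound 2 elsewhere as well, so it offers only a loose hint. Only a small step, leaning toward stronger inhibition and possibly within the scatter, is expected: a 1.9-fold lower number from compound 2 to compound 3 (0.29 log units; within the scatter). For compound 3 the estimate is 700 nM, with a range from 200 nM to 2500 nM.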

Compound 3, half-maximal inhibitory concentration: 220 nM
Compound 3: middle estimate off by 3.2-fold (0.50 log units), on the high side; low and high end bracket the measured number.
By their numbers in this assay, from the lowest: compounds 1 and 3 (each within the scatter of the next); then compound 2.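

On a carbonyl carbon whose other neighbour is a saturated ring carbon, 1,1-dioxothiomorpholin-4-yl in place of (oxan-4-yl)amino gives, in this assay, a 6.1-fold lower number from compound 2 to compound 3 (0.79 log units; beyond the scatter). Among the compounds shown here, this is the first comparison here that differs in one place only, and it shows that the group on this carbonyl carbon can change the read-out beyond the scatter. The swap alters several things at once, going from 1 hydrogen-bond donor to 0 and from 1 hydrogen-bond acceptor to 2, while adding a sulfur atom, and no measurement here shows which of these matters.

The compounds shown leave open whether the sulfur with its two oxygens is needed, or whether a plain morpholin-4-yl or thiomorpholin-4-yl group on the same carbonyl carbon would give a similar number. They also leave open whether the same swap would behave alike on the core of compound 1.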